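A few compounds are considered here, and "the series" means these few. Any claim that something is new, unique, unknown or untested is made for them only; others in the source may bear on it.

In a functional assay on FM3A cells (Mus musculus) for cytotoxicity (a lower number here means that less compound is needed, a higher number that more compound is needed for the effect), three compounds that share one core have been measured. Compound 1 `COOC1(OOC)CCCCCCCCCCC1` gives 1500 nM, compound 2 `C=C(C)COOC1(OOC)CCCCCCCCCCC1` gives 17000 nM, and compound 3 `COOC1(OOCCCCCCI)CCCCCCCCCCC1` gives 86000 nM, the highest number of the three. The next structure is compound 4 `COOC1(OOC(C)(C)OC)CCCCCCCCCCC1`, in which 1-methoxy-1-methylethyl stands in place of 6-iodohexyl on an oxygen: 1-methoxy-1-methylethyl in place of 6-iodohexyl on an oxygen.

Among the measured compounds shown here, three measured steps bear on this change. The first is an 11-fold higher number from compound 1 to compound 2 (1.05 log units; beyond the scatter), which is large. The second, also large, is a 57-fold higher number from compound 1 to compound 3 (1.76 log units; beyond the scatter). The third is a 5.1-fold higher number from compound 2 to compound 3 (0.70 log units; beyond the scatter), which is modest. Both replacements of a hydrogen in compound 1 thus raised the number, and neither of the other compounds goes against this, though two steps are a thin basis. For the measured compounds named here, no measured compound carries the 1-methoxy-1-methylethyl group, so its own contribution is unknown. Compound 4 is therefore expected to lie above compound 1, at 1500 nM, but to fall back from compound 3, landing near compound 2, at 17000 nM. The expected change, modest to large in size, is an 8.6-fold lower number from compound 3 to compound 4 (0.93 log units; beyond the scatter). For compound 4 the estimated value is 10000 nM, with an expected range from 2000 nM to 50000 nM.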

Compound 4, half-maximal effective concentration: 7300 nM
Compound 4: middle estimate off by 1.4-fold (0.14 log units), on the high side, within the range that was stated.
By their numbers in this assay, from the lowest: compound 1; then compound 4; then compound 2; then compound 3.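

In this assay, 1-methoxy-1-methylethyl is the first group on this oxygen shown to hold an oxygen of its own, and it puts compound 4 inside the span set by the other groups, with a 12-fold lower number from compound 3 to compound 4 (1.07 log units; beyond the scatter) when it replaces 6-iodohexyl and a 2.3-fold lower number from compound 2 to compound 4 (0.37 log units; beyond the scatter) when it replaces 2-methylprop-2-en-1-yl. The methyl group of compound 1 still gives the lowest number, and a 4.9-fold higher number from compound 1 to compound 4 (0.69 log units; beyond the scatter) shows that each of the three other groups at this place raises the number over methyl, none of the four compounds going against this, while the size of the rise depends strongly on the group. Nothing available accounts for these differences between the groups.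

The compounds shown leave open whether the high number of compound 3 goes with its iodine or with its chain, a question a plain hexyl chain would separate, and whether the oxygen of 1-methoxy-1-methylethyl plays any part, which 1,1-dimethylethyl would test. They also leave open whether any group at this place, such as an ethyl group or a chain ending in an amine, could bring the number level with or under that of compound 1.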